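Swapping One Group on a Carbonyl Carbon

This account rests on a few compounds, and the source may have more. Where it says the series, first, only, none or still open, it means among the compounds named here.

- Compound 1 `O=C1c2ccccc2C(=O)N1CCOC(=S)N(C(=O)c1ccc(F)c(F)c1)c1ccc(Cl)cc1` gives 52000 nM
- Compound 2 `O=C1c2ccccc2C(=O)N1CCOC(=S)N(C(=O)c1ccc(Cl)c([N+](=O)[O-])c1)c1ccc(Cl)cc1` gives 48000 nM
- Compound 3 `O=C1c2ccccc2C(=O)N1CCOC(=S)N(C(=O)c1cc2ccccc2s1)c1ccc(Cl)cc1` is not yet measured

In an ADME assay on MT4 cells (Homo sapiens) for cytotoxicity, read by MTT assay (on this read-out lower numbers stand for higher toxicity in this test and higher numbers for lower toxicity in this test), compound 2 stands within the usual scatter of repeated measurements from compound 1, so the two cannot be told apart. Compound 3 keeps the shared core and changes one group: 1-benzothiophen-2-yl in place of 4-chloro-3-nitrophenyl on a carbonyl carbon. Going by the values given here, only one measured step bears on this, a swap at the same place: a 1.1-fold lower number from compound 1 to compound 2 (0.03 log units; within the scatter). It is a single step, and it did not involve the entering group, so it is a thin guide. On that basis, no step beyond the scatter is expected in this assay, in either direction. The expected step is a 1.1-fold lower number from compound 2 to compound 3 (0.03 log units; within the scatter). For compound 3 the estimated value is 45000 nM, with an expected range from 20000 nM to 90000 nM.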

Compound 3, half-maximal cytotoxic concentration: 56000 nM
Compound 3: middle estimate off by 1.2-fold (0.09 log units), on the low side, and the stated range covers the measured number.
By their numbers in this assay, from the lowest: compounds 2, 1 and 3 (each within the scatter of the next).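

In this assay the step of a 1.2-fold higher number from compound 2 to compound 3 (0.07 log units; within the scatter) shows that a group of two fused aromatic rings holding sulfur, 1-benzothiophen-2-yl, can stand on this carbonyl carbon in place of the single-ring 4-chloro-3-nitrophenyl, and the two compounds cannot be told apart. The step of a 1.1-fold higher number from compound 1 to compound 3 (0.03 log units; within the scatter) reads the same way against 3,4-difluorophenyl, so the three groups tried at this place, including one with a second ring and no nitro group or halogen, give numbers that cannot be separated in this test. No measurement at hand accounts for this result.

On these data alone, all three groups are aromatic, so it stays open whether an open chain such as butyl, or a group carrying an amine or a carboxylic acid, would give a number outside this scatter. As far as these compounds go, it also stays open whether this place would respond the same way with the rest of the shared core altered.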